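The source may hold more compounds than are shown below. What is called first, only, known or untested is meant among the compounds shown, and "the series" means these compounds.

Measured so far in an assay for inhibition of Polyunsaturated fatty acid 5-lipoxygenase (Rattus norvegicus); on this read-out lower numbers stand for stronger inhibition and higher numbers for weaker inhibition:
compound 1 `C=CCc1cc2c(cc1O)C(C)(C)C(CCc1ccc(OC)cc1)O2`, 52 nM;
compound 2 `CCCc1cc2c(cc1O)C(C)(C)C(CCSc1ccccn1)O2`, 44 nM.

Compound 2 and compound 1 give numbers that lie within the scatter of each other, so neither stands apart in this assay. The step from compound 2 to compound 3 `CCCc1cc2c(cc1O)C(C)(C)C(CCc1ccc(SC)cc1)O2` is 4-(methylsulfanyl)phenyl in place of (pyridin-2-yl)sulfanyl on a saturated chain carbon, two bonds along the chain from a saturated ring carbon. Among the measured compounds shown here, no step between measured compounds is available to calibrate this change, and with compound 1 giving 52 nM for a related chain end, only a small step is expected, in either direction or none beyond the scatter. Compound 3 is therefore estimated at 50 nM, in the range 20 nM to 130 nM, a step of a 1.1-fold higher number from compound 2 to compound 3 (0.06 log units; within the scatter) expected to stay within the scatter.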

Compound 3, half-maximal inhibitory concentration: 92 nM
For compound 3 the middle estimate is 1.8-fold (0.26 log units) below the measured one; low and high end bracket the measured number.
By their numbers in this assay, from the lowest: compounds 2, 1 and 3 (each within the scatter of the next, the first and the last beyond it).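

In this assay, putting 4-(methylsulfanyl)phenyl in place of (pyridin-2-yl)sulfanyl on a saturated chain carbon gives a 2.1-fold higher number from compound 2 to compound 3 (0.32 log units; beyond the scatter). Among the compounds shown here, this is the first single-place step at this position, and it shows that the read-out responds to the chain end, though only modestly. Nothing available explains the step. The ring and the sulfur link change together in this step, and the compounds shown do not separate their contributions. On these data alone, how a chain end carrying an amine or a carboxylic acid would read remains open.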